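From Phenyl to 3-Aminophenyl on a Shared Core

The source may report more compounds than this note shows. Statements on the series, on what has been measured and on what is new or still open speak of the compounds shown alone.

In a functional assay on MCF7 cells (Homo sapiens) for cytotoxicity, read by MTT assay, with a stated time of 48 h (on this read-out lower numbers stand for stronger inhibition of growth and higher numbers for weaker inhibition of growth), compound 1 `CCn1c(C(F)(F)F)nc2cc(Cl)c(Cl)cc21` gives 72900 nM, compound 2 `FC(F)(F)c1nc2cc(Cl)c(Cl)cc2n1Cc1ccccc1` gives 8700 nM and compound 3 `O=[N+]([O-])c1ccccc1Cn1c(C(F)(F)F)nc2cc(Cl)c(Cl)cc21` gives 1500 nM. Compound 2 therefore holds the middle place among the three numbers. Compound 4 `Nc1cccc(Cn2c(C(F)(F)F)nc3cc(Cl)c(Cl)cc32)c1` has not yet been measured. It differs from compound 2 by amino in place of hydrogen on an aromatic carbon, meta to a large group: amino in place of hydrogen on an aromatic carbon.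

Among the compounds with values here, two measured steps bear on this change. The closer one is a 5.8-fold lower number from compound 2 to compound 3 (0.76 log units; beyond the scatter), where nitro takes the place of hydrogen on an aromatic carbon. The other is an 8.4-fold lower number from compound 1 to compound 2 (0.92 log units; beyond the scatter), where phenyl takes the place of methyl. Neither step involves an amino group, so both are only loose guides. A smaller step towards a lower number is therefore expected, estimated as a 2.5-fold lower number from compound 2 to compound 4 (0.40 log units; beyond the scatter) in this assay. Compound 4 is expected to give 3500 nM, within an estimated range of 1000 nM to 12000 nM.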

Compound 4, concentration for 50% growth inhibition: 77500 nM
Compound 4: middle estimate off by 22-fold (1.35 log units), on the low side; the measured number lies above the stated range.
By their numbers in this assay, from the lowest: compound 3; then compound 2; then compounds 1 and 4 (each within the scatter of the next).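

In this assay, adding a group to the phenyl ring of compound 2 does not always lower the number: amino, meta to a large group, gives an 8.9-fold higher number from compound 2 to compound 4 (0.95 log units; beyond the scatter), the opposite direction to the nitro step of a 5.8-fold lower number from compound 2 to compound 3 (0.76 log units; beyond the scatter). With a 1.1-fold higher number from compound 1 to compound 4 (0.03 log units; within the scatter), 3-aminophenyl cannot be told apart from methyl on this read-out, so the advantage that phenyl showed over methyl is lost once the amino group is present. Nothing measured here accounts for this reversal.

The compounds shown leave open whether the reversal follows the amino group itself or its place on the ring, since the nitro group of compound 3 sits elsewhere. They also leave open how a methoxy group or a carboxylic acid at the same carbon would behave.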